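Sulfur for selenium on the central carbon: series notes

A few compounds are considered here, and "the series" means these few. Any claim that something is new, unique, unknown or untested is made for them only; others in the source may bear on it.

Measured so far in a functional assay on PC-3 cells (Homo sapiens) for cytotoxicity, read by MTT assay, with a stated time of 72 h; a higher number here means a weaker inhibitor of growth, a lower number a stronger inhibitor of growth:
compound 1 `C[Se]/C(=N\C(=O)c1cc2ccccc2s1)NC(=O)c1cc2ccccc2s1` gives 65600 nM
compound 2 `C[Se]/C(=N\C(=O)c1sccc1Cl)NC(=O)c1sccc1Cl` gives 7030 nM

Among the compounds with values here, compound 2 stands at the lowest of the two numbers in this assay; its only neighbour is compound 1, whose number is higher by a margin beyond the usual scatter. Within the data shown here, no pair of measured compounds differs in a single place, so nothing can be said of the size of a single structural step from these two values alone; they only show that compound 2 is the stronger grower inhibitor of the pair.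

Compound 3 `CS/C(=N\C(=O)c1sccc1Cl)NC(=O)c1sccc1Cl` is not yet measured in this assay. It keeps the core of compound 2 and differs in one place: a group of 2 heavy atoms (1 carbon, 1 sulfur; no ring) in place of a group of 2 heavy atoms (1 carbon, 1 selenium; no ring), on a carbon with a double bond to nitrogen. Among the measured compounds shown here, no measured step covers this kind of exchange, so the expectation rests on the general observation that a group of one carbon and one selenium and a group of one carbon and one sulfur are of the same size and shape. The step from compound 2 to compound 3 is expected to be a modest loss, a 2.1-fold higher number from compound 2 to compound 3 (0.33 log units; beyond the scatter), in this assay. Compound 3 is estimated at 15000 nM, with a range from 5000 nM to 60000 nM.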

Compound 3, concentration for total growth inhibition: 57400 nM
Estimate against measurement, compound 3: 3.8-fold (0.58 log units) below; the measured number falls inside the stated range.
By their numbers in this assay, from the lowest: compound 2; then compounds 3 and 1 (each within the scatter of the next).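

In this assay, methylsulfanyl in place of the selenium-bearing group, on a carbon with a double bond to nitrogen whose other neighbours are two amide-type nitrogens, gives an 8.2-fold higher number from compound 2 to compound 3 (0.91 log units; beyond the scatter). Within the data shown here, this is the first step that changes a single place, and it shows that this position is not indifferent to the exchange: the entering and leaving groups have the same count of heavy atoms and neither carries a ring or a net charge, yet growth inhibition is clearly weaker with sulfur than with selenium, so the selenium-bearing group is the better of the two on this core. Nothing measured on these compounds accounts for the size of this step, and no explanation can be offered from the numbers alone.

On these data alone, whether the exchange gives a step of similar size on the core of compound 1 remains open, since a single pair cannot show how far the effect carries to other cores. Also open, as far as these compounds go, is how this position responds to groups of a different kind, such as an amine or a longer chain like ethylsulfanyl.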